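A few compounds are considered here, and "the series" means these few. Any claim that something is new, unique, unknown or untested is made for them only; others in the source may bear on it.

In a functional assay on MGC-803 cells (Homo sapiens) for inhibition, read by MTT assay, with a stated time of 48 h (a higher number here means a weaker inhibitor, a lower number a stronger inhibitor), compound 1 `C/C=C/C(=O)N(Cc1ccc(OC)c([N+](=O)[O-])c1)c1cc(OC)c(OC)c(OC)c1` gives 590 nM and compound 3 `COc1ccc(CN(C(C)=O)c2cc(OC)c(OC)c(OC)c2)cc1O` gives 79 nM. Compound 2 `COc1cc(NCc2ccccc2)cc(OC)c1OC`, a secondary amine rather than an amide, gives > 80000 nM, which is a limit and not a number, and so it stands at the limit of > 80000 nM in this assay, at which 1 of the 3 values shown sits. Compound 4 `COc1cc(NCc2ccc(Cl)cc2)cc(OC)c1OC` turns the phenyl of compound 2 into 4-chlorophenyl: chloro in place of hydrogen on an aromatic carbon. Within the data shown here, no measured pair shows what this change does in this assay, so the expectation is cautious. The expected change is small and towards stronger inhibition, an estimated at least 1.3-fold lower number from compound 2 to compound 4 (0.12 log units; that floor lies within the scatter). For compound 4 the estimate is 60000 nM, with an expected range of 15000 nM to 120000 nM.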

Compound 4, half-maximal inhibitory concentration: > 80000 nM
Compound 4 was reported as a limit; the forecaster's own chance of this, stated with the estimate: 60%; at least 1.3-fold (0.12 log units) between middle value and limit.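

Compound 2 and compound 4 both stand at a limit in this assay, so no step can be read between them: the limit of > 80000 nM in this assay, at which 2 of the 4 values shown sit.

The compounds shown leave open what 4-chlorophenyl in place of phenyl does to inhibition.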